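A few compounds are considered here, and "the series" means these few. Any claim that something is new, unique, unknown or untested is made for them only; others in the source may bear on it.

Measured so far in a functional assay on A549 cells (Homo sapiens) for antiproliferative activity, read by MTT assay, with a stated time of 72 h; on this read-out higher numbers stand for weaker inhibition and lower numbers for stronger inhibition:
Compound 1 `O=C(CCCCCCc1nc(-c2ccc(F)cc2)no1)NO`: 5770 nM
Compound 2 `O=C(CCCCCCc1nc(-c2ccccc2Cl)no1)NO`: 8870 nM

Among the compounds with values here, compound 1 sits level with compound 2, the only other measured compound, as a 1.5-fold higher number from compound 1 to compound 2 (0.19 log units; within the scatter) shows. Next in line is compound 3 `O=C(CCCCCCc1nc(-c2ccc(F)cc2)no1)C(F)(F)F`, which keeps the core of compound 1 and changes one group: trifluoromethyl in place of hydroxyamino on a carbonyl carbon. Within the data shown here, the only measured step, a 1.5-fold higher number from compound 1 to compound 2 (0.19 log units; within the scatter), concerns a group on an aromatic carbon, not the carbonyl carbon, so it gives no size for this change. Among the measured compounds shown here, both measured compounds carry hydroxyamino, and no measured compound lacks it. The replacement is therefore untested, and a shift toward weaker inhibition in this assay is expected, beyond the scatter but with wide uncertainty. The estimated step is a 4.3-fold higher number from compound 1 to compound 3 (0.64 log units; beyond the scatter). For compound 3 the expected value is 25000 nM, with an estimated range of 7000 nM to 90000 nM.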

Compound 3, half-maximal inhibitory concentration: > 100000 nM
Compound 3: no number, only a limit (the forecaster's own chance of this, stated with the estimate: 25%); middle value at least 4.0-fold (0.60 log units) away from the limit.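

In this assay, trifluoromethyl in place of hydroxyamino on the carbonyl carbon gives an at least 17-fold higher number from compound 1 to compound 3 (1.23 log units; beyond the scatter) and so marks this position as one where a single change has a large effect on the read-out. Within the data shown here, the only earlier step, a 1.5-fold higher number from compound 1 to compound 2 (0.19 log units; within the scatter) on an aromatic carbon, gave no reading of this position, and all earlier compounds carried hydroxyamino. Compound 3 gives > 100000 nM as a limit of the assay, not a number, so the step has a floor and no upper end: the limit of > 100000 nM in this assay, at which 1 of the 3 values shown sits.

Still open, as far as these compounds go, is whether other groups on the same carbonyl carbon, such as a hydroxy group (the carboxylic acid), a methoxy group or an amino group, fall as far as trifluoromethyl. Also open, from the compounds shown here alone, is how a longer chain in place of the saturated chain of compound 1 would read.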